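The compounds below may be only part of what the source reports. "The series", "measured", "known", "first", "only" and "open" are said of these compounds alone.

Three compounds share one core and differ only in the aromatic group attached to it. In an assay on HEK293 cells for activation of Kir3.1/Kir3.2 (Homo sapiens), read by thallium flux (on this read-out higher numbers stand for an effect only at larger amounts of compound and lower numbers for an effect already at smaller amounts), compound 1 `Cc1cc(NC(=O)Cn2nnc(-c3cc(Cl)cc(Cl)c3)n2)n(C2CCCCC2)n1` gives 980 nM, compound 2 `Cc1cc(NC(=O)Cn2nnc(-c3ccc(F)c(F)c3)n2)n(C2CCCCC2)n1` gives 116 nM, and compound 3 `Cc1cc(NC(=O)Cn2nnc(-c3ccnc(F)c3)n2)n(C2CCCCC2)n1` gives 441 nM. Compound 3 thus stands second highest of the three, with a 2.2-fold lower number from compound 1 to compound 3 (0.35 log units; beyond the scatter) and a 3.8-fold higher number from compound 2 to compound 3 (0.58 log units; beyond the scatter). Compound 4 `COc1ccc(-c2nnn(CC(=O)Nc3cc(C)nn3C3CCCCC3)n2)cc1` carries 4-methoxyphenyl in place of 2-fluoropyridin-4-yl on an aromatic carbon. Among the measured compounds shown here, no measured step brings in a methoxyphenyl, so the aryl exchanges seen so far, an 8.4-fold lower number from compound 1 to compound 2 (0.93 log units; beyond the scatter) among them, show only that such swaps shift the number modestly. Moving back to a ring of carbon only resembles reversing the step of a 3.8-fold higher number from compound 2 to compound 3 (0.58 log units; beyond the scatter), so a modest drop is expected, a 2.0-fold lower number from compound 3 to compound 4 (0.30 log units; within the scatter). Compound 4 is therefore estimated at 220 nM, within 60 nM to 800 nM.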

Compound 4, half-maximal effective concentration: 175 nM
The estimate for compound 4 lay 1.3-fold (0.10 log units) above the measured number; the range from low to high includes it.
By their numbers in this assay, from the lowest: compounds 2 and 4 (each within the scatter of the next); then compound 3; then compound 1.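

Placing 4-methoxyphenyl on this aromatic carbon gives a 2.5-fold lower number from compound 3 to compound 4 (0.40 log units; beyond the scatter) and a 5.6-fold lower number from compound 1 to compound 4 (0.75 log units; beyond the scatter), while a 1.5-fold higher number from compound 2 to compound 4 (0.18 log units; within the scatter) leaves it level with the 3,4-difluorophenyl group. In this assay, a ring of carbon only that carries neither fluorine nor chlorine thus reaches the same range as compound 2, so halogens are not required here among these compounds. Nothing available explains this result. Still open, from the compounds shown here alone, is how a plain phenyl, or a phenyl carrying an amine or a carboxylic acid, would behave on this carbon. Going by these compounds, whether a longer chain such as ethoxy could replace the methoxy group also remains unknown.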